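Urea series on the shared core: ring swap to thiophene

The compounds below may be only part of what the source reports. "The series", "measured", "known", "first", "only" and "open" are said of these compounds alone.

Three ureas on a shared core have been measured in an assay on microsomes from intestine for inhibition of acyl-CoA:cholesterol acyltransferase (Oryctolagus cuniculus); on this read-out lower numbers stand for stronger inhibition and higher numbers for weaker inhibition. Compound 1 `CC(C)c1cccc(C(C)C)c1NC(=O)NCc1ccccc1` gives 360 nM. Compound 2 `CC(C)c1cccc(C(C)C)c1NC(=O)NC1CCCc2ccccc21` gives 850 nM. Compound 3 `CC(C)c1cccc(C(C)C)c1NC(=O)NCC1(c2cccnc2)CCCC1` gives 97 nM, the lowest number of the three; its gap to compound 1 and its larger gap to compound 2 both lie beyond the usual scatter, so compound 3 stands as the strongest inhibitor among the measured compounds.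

Compound 4 `CC(C)c1cccc(C(C)C)c1NC(=O)NCC1(c2ccsc2)CCCC1` has not been measured. It differs from compound 3 by thiophen-3-yl in place of pyridin-3-yl on a saturated ring carbon. Among the compounds with values here, no pair of measured compounds isolates this exchange: compound 1, compound 2 and compound 3 each carry a wholly different group on the urea nitrogen, so the measured set gives no direct reading of what swapping one aromatic ring for another does here. Given that, the expected step is a 1.2-fold higher number from compound 3 to compound 4 (0.09 log units; within the scatter), a step of a size that stays within the scatter, in no firm direction. Compound 4 is therefore expected to give about 120 nM in this assay, with a range from 40 nM to 360 nM.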

Compound 4, half-maximal inhibitory concentration: 18 nM
The estimate for compound 4 lay 6.7-fold (0.82 log units) above the measured number; measured number outside the range, below it.
By their numbers in this assay, from the lowest: compound 4; then compound 3; then compound 1; then compound 2.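

Within the data shown here, the step of a 5.4-fold lower number from compound 3 to compound 4 (0.73 log units; beyond the scatter) in this assay comes from the first pair that differs in one place, and it shows that the number at this position depends on which aromatic ring sits on the saturated ring carbon. The direction also favours the exchange, with thiophen-3-yl giving the lower number and so the stronger inhibition of the two. The change alters ring size and hetero atom together, with a six-membered aromatic ring carrying nitrogen leaving and a five-membered aromatic ring carrying sulfur entering, and no measurement shown here explains the step.

Still open, going by these compounds, is whether the lower number tracks ring size or the hetero atom, a question that phenyl, furan-3-yl and thiophen-2-yl on the same saturated ring carbon would help to separate. Also open, on these data alone, is whether the step between these two aromatic rings holds when a cyclohexane ring or a plain gem-dimethyl carbon replaces the five-membered non-aromatic ring of carbon only.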